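Series notes: hydrogen in place of acetyl on an oxygen

The compounds below may be only part of what the source reports. "The series", "measured", "known", "first", "only" and "open" are said of these compounds alone.

Of the compounds shown here, two have been measured in a functional assay on cells (Monocyte, Homo sapiens) for inhibition; a higher number here means a weaker inhibitor, a lower number a stronger inhibitor. Compound 1 `CCC[C@@H](OC(C)=O)C1=C(Br)/C(=C/Br)OC1=O` gives 3000 nM in this assay. Compound 2 `CCCCC1=C(Br)C(=C(Br)Br)OC1=O` gives 3000 nM in this assay. On these numbers compound 1 stands level with compound 2 at the digits shown, a gap that lies within the usual scatter of repeat measurements, so no order between the two can be read. Within the data shown here, no pair of measured compounds differs in a single place, and therefore no measured step is known on which to lean.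

Compound 3 `CCC[C@@H](O)C1=C(Br)/C(=C/Br)OC1=O` has not yet been measured in this assay. Its difference from compound 1 is hydrogen in place of acetyl on an oxygen on a saturated carbon. Among the measured compounds shown here, with no measured precedent for this change, the step from compound 1 to compound 3 is expected to be small, estimated at a 1.2-fold higher number from compound 1 to compound 3 (0.07 log units; within the scatter), with no direction that is expected to exceed the scatter. Compound 3 is therefore expected to give about 3500 nM in this assay, with an estimated range from 1000 nM to 12000 nM.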

Compound 3, half-maximal inhibitory concentration: 1500 nM
The estimate for compound 3 lay 2.3-fold (0.37 log units) above the measured number; low and high end bracket the measured number.
By their numbers in this assay, from the lowest: compounds 3, 1 and 2 (each within the scatter of the next).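

The acetoxy to hydroxy change gives the series its first single-place step in this assay, and it reads as a 2.0-fold lower number from compound 1 to compound 3 (0.30 log units; within the scatter) with no order between the two compounds. On this one pair, the acetyl on the oxygen on a saturated carbon is not needed for inhibition in this assay, since the free hydroxy compound stays in the same range of values, and the position accepts the loss of all the acetyl heavy atoms without a change beyond the scatter. Nothing available explains the size of this step or connects it to any property of either group.

The compounds shown carry only acetyl or hydrogen on this oxygen, so a single pair says nothing about how wide the tolerance is, and a methyl ether, a longer acyl chain such as butanoyl, or an amine in place of the oxygen could each behave differently. From the compounds shown here alone, whether the position can move the number beyond the scatter in either direction stays open, as does whether the same change would read alike on a different core.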